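The source may hold more compounds than are shown below. What is called first, only, known or untested is meant among the compounds shown, and "the series" means these compounds.

Measured so far:
compound 1 `CC1=C([Se]CC(OC(=O)[C@@H](CO)NC(=O)OC(C)(C)C)C(=O)NC(C)(C)C)C(=O)c2ccccc2C1=O` — 3000 nM
compound 2 `CC1=C([Se]CC(OC(=O)[C@@H](CO)NC(=O)OC(C)(C)C)C(=O)NCCCCCC(=O)OCc2ccccc2)C(=O)c2ccccc2C1=O` — 35000 nM

In an ADME assay on HUVEC cells (Homo sapiens) for cytotoxicity, read by MTT assay, with a stated time of 24 h (on this read-out higher numbers stand for weaker inhibition and lower numbers for stronger inhibition), compound 1 gives 3000 nM, the lower of the two numbers; compound 2 gives 35000 nM, a higher number that lies beyond the scatter. Compound 3 `CC1=C([Se]CC(OC(=O)[C@@H](CSSC(C)(C)C)NC(=O)OC(C)(C)C)C(=O)NC(C)(C)C)C(=O)c2ccccc2C1=O` is not yet measured. It differs from compound 1 by ((tert-butyl)sulfanyl)sulfanyl in place of hydroxy on a saturated chain carbon, two bonds along the chain from an amide-type nitrogen and a carbonyl carbon. Going by the values given here, no step between measured compounds isolates this change, so the direction is open; the expected step of a 1.2-fold lower number from compound 1 to compound 3 (0.08 log units; within the scatter) is small, perhaps within the scatter. For compound 3 the estimate in this assay is 2500 nM, with a range from 800 nM to 8000 nM.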

Compound 3, half-maximal inhibitory concentration: 2000 nM
For compound 3 the middle estimate is 1.3-fold (0.10 log units) above the measured one; the range from low to high includes it.
By their numbers in this assay, from the lowest: compounds 3 and 1 (each within the scatter of the next); then compound 2.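

In this assay, going by these compounds alone, the saturated chain carbon, two bonds along the chain from an amide-type nitrogen and a carbonyl carbon, gives the first readable step: a 1.5-fold lower number from compound 1 to compound 3 (0.18 log units; within the scatter). At this position, therefore, ((tert-butyl)sulfanyl)sulfanyl in place of hydroxy, with no hydrogen-bond donor in the entering group, leaves the two numbers within the scatter of each other. No supporting measurement accounts for this result.

From the compounds shown here alone, whether an amine or a carboxylic acid at this carbon would also stay within the scatter remains open. Also open, going by these compounds, is whether ((tert-butyl)sulfanyl)sulfanyl gives the same result with the longer amide chain of compound 2.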